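The compounds below may be only part of what the source reports. "The series", "measured", "known", "first", "only" and "open" are said of these compounds alone.

Of the compounds shown here, three built on a shared core have been measured in a functional assay on M21 cells (Homo sapiens) for antiproliferative activity, read by sulforhodamine B assay, with a stated time of 48 h; a lower number here means a stronger inhibitor, a higher number a weaker inhibitor. Compound 1 `CCCCOc1ccc(NS(=O)(=O)c2ccc(N3CCNC3=O)cc2)cc1` gives 580 nM in this assay. Compound 2 `COc1ccccc1NS(=O)(=O)c1ccc(N2CCNC2=O)cc1` gives 300 nM, a number that sits within the usual scatter of the value of compound 1. Compound 3 `O=C1NCCN1c1ccc(S(=O)(=O)Nc2cccc(Oc3ccccc3)c2)cc1` gives 83 nM, the lowest of the three and beyond the scatter from the value of compound 1. Among these three numbers compound 1 therefore stands highest, with compound 2 nearest to it and compound 3 furthest from it.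

Compound 4 `CCCCCCCc1ccc(NS(=O)(=O)c2ccc(N3CCNC3=O)cc2)cc1` has not yet been measured. It differs from compound 1 in one place: heptyl in place of butoxy on an aromatic carbon. Among the measured compounds shown here, no two of the measured compounds differ in a single place, so there is no measured step that speaks directly to this change. For the measured compounds named here, the measured values show only that the group on this ring matters, as the gap between compound 1 and compound 3 makes plain, but they give no direction for an exchange of this kind. In this assay the expected step is a 1.2-fold lower number from compound 1 to compound 4 (0.06 log units; within the scatter), none beyond the scatter. Compound 4 is accordingly expected to give 500 nM in this assay, with a likely range from 150 nM to 1800 nM.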

Compound 4, half-maximal inhibitory concentration: > 1000 nM
Compound 4 was reported as a limit (the forecaster's own chance of this, stated with the estimate: 5%); middle value at least 2.0-fold (0.30 log units) from the limit.
By their numbers in this assay, from the lowest: compound 3; then compounds 2 and 1 (each within the scatter of the next). At a limit, above all of these: compound 4.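

Among the compounds shown here, the exchange of butoxy for heptyl on an aromatic carbon, para to a large group, gives the first step in which only one place changes, and in this assay it reads as an at least 1.7-fold higher number from compound 1 to compound 4 (0.23 log units; that floor lies within the scatter). Going by these compounds, compound 4 is reported only as a limit, not as a number, so this step is a floor and its full size remains unknown: the limit of > 1000 nM in this assay, at which 1 of the 4 values shown sits. The result gives this position a first direction, since the exchange of a chain carrying one hydrogen-bond acceptor for a longer all-carbon chain brings no lower number, although the floor alone does not carry the step beyond the scatter.

The compounds shown change the chain length and the oxygen together, so they leave open which of the two matters, a question that butyl or heptyloxy at the same place, each changing only one of them, could help to separate. They also leave open how a chain ending in an amine or a carboxylic acid would read in this assay.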